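This account rests on a few compounds, and the source may have more. Where it says the series, first, only, none or still open, it means among the compounds named here.

Measured so far in a functional assay on the whole organism (strain Wistar) for inhibition, with Rattus norvegicus as the target, read by paw edema, with stated times of 30 min and 3 h, at a dose of 200 mg/kg by the oral route; a higher number here means more inhibition at the dose given (going by the name of the read-out), a lower number less inhibition: compound 1 `O=C(O)c1cc(-n2c(-c3ccc(Cl)c(Cl)c3)cc3c2CCCC3)ccc1O` gives 0%, and compound 2 `O=C(O)c1cc(-n2c(-c3ccc(O)cc3)cc3c2CCCC3)ccc1O` gives 20%.

Compound 2 stands highest of the two numbers; its nearest neighbour is compound 1, with a number 20 percentage points higher from compound 1 to compound 2 (beyond the scatter) between them. Compound 3 `O=C(O)c1cc(-n2c(-c3cccs3)cc3c2CCCC3)ccc1O` is not yet measured. It differs from compound 2 in one place: thiophen-2-yl in place of 4-hydroxyphenyl on an aromatic carbon. Going by the values given here, the single step on record, a number 20 percentage points higher from compound 1 to compound 2 (beyond the scatter), set the 4-hydroxyphenyl of compound 2 above the 3,4-dichlorophenyl of compound 1. With the 4-hydroxyphenyl leaving again, a downward step in this assay is expected, a number 12 percentage points lower from compound 2 to compound 3 (beyond the scatter). Compound 3 is estimated at 8%, range 0% to 25%.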

Compound 3, a percentage reported as inhibition, in the whole organism at one dose (the size of the read-out at that dose, not a potency): 30%
Estimate against measurement, compound 3: 22 percentage points below; the whole stated range lies below it.
By their numbers in this assay, from the lowest: compound 1; then compounds 2 and 3 (each within the scatter of the next).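

On the aromatic carbon next to the ring nitrogen, 3,4-dichlorophenyl can be replaced by more than one group in this assay: thiophen-2-yl gives a number 30 percentage points higher from compound 1 to compound 3 (beyond the scatter). Set against 4-hydroxyphenyl, the same group gives a number 10 percentage points higher from compound 2 to compound 3 (within the scatter), so the hydrogen-bond donor of compound 2 is not required to hold this level. Nothing on record accounts for these differences.

Still open, as far as these compounds go, is how a pyridin-3-yl or a small methyl group would read at this position. Also open, from the compounds shown here alone, is whether thiophen-3-yl would match thiophen-2-yl.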